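This account rests on a few compounds, and the source may have more. Where it says the series, first, only, none or still open, it means among the compounds named here.

Three glycolipids carrying a long alkyl or alkenyl chain on the anomeric oxygen of an acetamido- or pentanamido-sugar were examined in a functional assay on C6 cells (Rattus norvegicus), read by thymidine incorporation; on this read-out lower numbers stand for stronger inhibition and higher numbers for weaker inhibition. Compound 1 `CCCCCCCC/C=C\CCCCCCCCO[C@H]1O[C@H](CO)[C@@H](O)[C@H](O)[C@H]1NC(C)=O` gives 1.3 uM in this assay. Compound 2 `CCCCCCCCCCCCCCCCO[C@H]1O[C@H](COCC(CO)(CO)COS(=O)(=O)O)[C@@H](O)[C@H](O)[C@H]1NC(=O)CCCC` gives 11 uM, and compound 3 `CCCCCCCCCCCCCCCCO[C@H]1O[C@H](COCC(CO)(CO)CO)[C@@H](O)[C@H](O)[C@H]1NC(=O)CCCC` gives 18.3 uM. Among these three, compound 1 has the lowest number, and its distance to both compound 2 and compound 3 lies beyond the scatter.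

Compound 3 and compound 2 differ in one place: sulfo in place of hydrogen on an oxygen on a saturated carbon. This change gave a 1.7-fold lower number from compound 3 to compound 2 (0.22 log units; within the scatter).

Compound 4 `CCCCCCCC/C=C\CCCCCCCCO[C@H]1O[C@H](CO)[C@@H](O)[C@H](OS(=O)(=O)O)[C@H]1NC(C)=O` is not yet measured. It is related to compound 1 by sulfo in place of hydrogen on an oxygen on a saturated carbon. The difference between the core of compound 1 and the core of compound 3 is not broken down here. The surroundings of the changed position also differ: in compound 2 the oxygen sits on a saturated carbon whose other neighbour is a saturated chain carbon, whereas in compound 4 it sits on a saturated carbon whose other neighbour is a saturated ring carbon, so the two are the same kind of change rather than the same change.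

Because the step of a 1.7-fold lower number from compound 3 to compound 2 (0.22 log units; within the scatter) stayed within the scatter, compound 4 is expected to stay close to compound 1, with an estimated step of a 1.3-fold lower number from compound 1 to compound 4 (0.11 log units; within the scatter). For compound 4 the estimated value in this assay is 1 uM, expected to fall between 0.4 uM and 3 uM.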

Compound 4, concentration for 50% inhibition: 12.3 uM
Estimate against measurement, compound 4: 12-fold (1.09 log units) below, and the stated range ends below it.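

On the core of compound 1, sulfo in place of hydrogen gave a 9.5-fold higher number from compound 1 to compound 4 (0.98 log units; beyond the scatter) in this assay, so inhibition was weaker on this core, and the two instances of the change do not agree: the same change on two cores in this assay, a 1.7-fold lower number (0.22 log units; within the scatter) from compound 3 to compound 2 and a 9.5-fold higher number (0.98 log units; beyond the scatter) from compound 1 to compound 4, 16-fold (1.20 log units) apart, beyond the scatter of two such steps This shows that, in this series, the small step seen on one core could not be carried over to the other, and that the size of this change depended on the compound pair that carried it. It does not show what separates the two pairs, since they differ both in their cores and in the surroundings of the changed oxygen, which has a saturated chain carbon as its neighbour in compound 2 and a saturated ring carbon in compound 4, and each instance rests on a single pair.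

The compounds shown leave open whether the larger step belongs to the core of compound 1 or to the ring position of the sulfo group, a question that the same group on another oxygen of that core could address. They also leave open whether a carboxylic acid or a phosphate in that place would give a step like that of the sulfo group.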